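Swapping the alkyl group on the boron-bearing carbon

A few compounds are considered here, and "the series" means these few. Any claim that something is new, unique, unknown or untested is made for them only; others in the source may bear on it.

Values in a functional assay on HCT-116 cells (Homo sapiens) for antiproliferative activity, read by MTT assay, with a stated time of 72 h (a higher number here means a weaker inhibitor, a lower number a stronger inhibitor), follow
compound 1 `CCC[C@H](NC(=O)N1C/C(=C\c2ccc(F)cc2)C(=O)/C(=C/c2ccc(F)cc2)C1)B1OC(C)(C)C(C)(C)O1` gives 785 nM
compound 2 `CC(C)(C)[C@H](NC(=O)N1C/C(=C\c2ccc(F)cc2)C(=O)/C(=C/c2ccc(F)cc2)C1)B1OC(C)(C)C(C)(C)O1` gives 828 nM
compound 3 `CC(C)[C@H](NC(=O)N1C/C(=C\c2ccc(F)cc2)C(=O)/C(=C/c2ccc(F)cc2)C1)B1OC(C)(C)C(C)(C)O1` gives 908 nM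

Compound 3 sits with the other two, its value within the scatter of both, as a 1.2-fold higher number from compound 1 to compound 3 (0.06 log units; within the scatter) and a 1.1-fold higher number from compound 2 to compound 3 (0.04 log units; within the scatter) show . Compound 4 `CC(C)C[C@H](NC(=O)N1C/C(=C\c2ccc(F)cc2)C(=O)/C(=C/c2ccc(F)cc2)C1)B1OC(C)(C)C(C)(C)O1` carries isobutyl in place of isopropyl on a saturated chain carbon bound to an amide-type nitrogen and a boron atom, isobutyl in place of isopropyl on a saturated chain carbon bound to an amide-type nitrogen and a boron atom . The closest evidence is those same two steps, joined by a 1.1-fold higher number from compound 1 to compound 2 (0.02 log units; within the scatter), and none goes beyond the scatter . Propyl, tert-butyl and isopropyl give values that cannot be told apart, so the step expected here is a 1.1-fold lower number from compound 3 to compound 4 (0.05 log units; within the scatter), with nothing beyond the scatter anticipated . Compound 4 is estimated at 800 nM, with an expected range from 450 nM to 1400 nM.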

Compound 4, half-maximal inhibitory concentration: 824 nM
Estimate against measurement, compound 4: 1.0-fold (0.01 log units) below, and the stated range covers the measured number.
By their numbers in this assay, from the lowest: compounds 1, 4, 2 and 3 (each within the scatter of the next).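

With isobutyl, four alkyl groups have now been compared on the saturated chain carbon bound to an amide-type nitrogen and a boron atom, and in this assay the new group stays within the scatter of all three others: a 1.1-fold lower number from compound 3 to compound 4 (0.04 log units; within the scatter), a 1.0-fold lower number from compound 2 to compound 4 (0.00 log units; within the scatter) and a 1.0-fold higher number from compound 1 to compound 4 (0.02 log units; within the scatter). Hydrogen in place of methyl can now be read twice, and it again stays within the scatter: the same change on two cores in this assay, a 1.1-fold higher number (0.04 log units; within the scatter) from compound 2 to compound 3 and a 1.0-fold lower number (0.02 log units; within the scatter) from compound 4 to compound 1, 1.2-fold (0.06 log units) apart, within the scatter of two such steps. As far as these compounds go, all four groups are saturated alkyl groups, so it remains open whether a phenyl ring, an amine or a carboxylic acid at this place would move the number beyond the scatter.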